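The source may hold more compounds than are shown below. What is called first, only, known or untested is meant among the compounds shown, and "the series" means these compounds.

Working notes on the series. Two thiosemicarbazones on a shared core have been run in a functional assay on HeLa cells (Homo sapiens) for antiproliferative activity, read by sulforhodamine B assay, with a stated time of 72 h; on this read-out higher numbers stand for weaker inhibition and lower numbers for stronger inhibition. Compound 1 `NC(=S)N/N=C/c1ccc2ccccc2n1` gives 960 nM in this assay. Compound 2 `NC(=S)N/N=C/c1cnc2ccccc2n1` returns only a limit of the assay, > 100000 nM, and no number. For the measured compounds named here, compound 1 therefore holds the only number in the set so far; the other value sits at the limit of > 100000 nM in this assay, at which 1 of the 2 values shown sits, and no step between measured compounds can be read from these two.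

Compound 3 `S=C(N/N=C/c1ccc2ccccc2n1)Nc1ccccc1` has not yet been measured. It differs from compound 1 by phenyl in place of hydrogen on an amide-type nitrogen. Going by the values given here, no measured pair in the set covers a change of this kind, so the direction rests on the structural change alone. The step from compound 1 to compound 3 is expected to be small and toward stronger inhibition, a 1.9-fold lower number from compound 1 to compound 3 (0.28 log units; within the scatter), though an outcome within the scatter would not be surprising. For compound 3 the estimate in this assay is 500 nM, with a range from 100 nM to 2500 nM.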

Compound 3, half-maximal inhibitory concentration: 27400 nM
Beside the measured number, compound 3's estimate is 55-fold (1.74 log units) below it; measured number outside the range, above it.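

In this assay, for the compounds shown here, phenyl in place of hydrogen on an amide-type nitrogen brings a 29-fold higher number from compound 1 to compound 3 (1.46 log units; beyond the scatter) and this is the first step that can be read as a number. It shows that this nitrogen is not indifferent to substitution: the amino form in compound 1 is clearly favoured over the anilino form in compound 3, although compound 3 still returns a measurable value rather than a limit. Nothing measured in the set accounts for the size of this step.

Going by these compounds, whether the loss belongs to phenyl in particular or to any group on this nitrogen remains open, and a methyl or a benzyl at the same place would separate the two readings. Also open, on these data alone, is whether a phenyl carrying an amine or a carboxylic acid would recover any of the lost inhibition.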